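The source may hold more compounds than are shown below. What is called first, only, known or untested is meant among the compounds shown, and "the series" means these compounds.

Measured in a functional assay on HepG2 cells (Homo sapiens) for cytotoxicity, read by MTT assay, with a stated time of 24 h; a higher number here means a weaker inhibitor, a lower number a stronger inhibitor:
Compound 1 `O=C1/C(=C/c2ccncc2)CNC/C1=C\c1ccccc1C(F)(F)F`: 6130 nM
Compound 2 `O=C1/C(=C/c2ccncc2)CN(S(=O)(=O)c2ccc(F)cc2)C/C1=C\c1ccccc1C(F)(F)F`: 4010 nM
Compound 3 `O=C1/C(=C/c2ccncc2)CN(S(=O)(=O)c2ccc(Br)cc2)C/C1=C\c1ccccc1C(F)(F)F`: 14500 nM

Compound 3 stands highest of the three at 14500 nM. The next change gives compound 4 `N#Cc1ccc(S(=O)(=O)N2C/C(=C\c3ccncc3)C(=O)/C(=C/c3ccccc3C(F)(F)F)C2)cc1`, with cyano in place of bromo on an aromatic carbon, para to a large group (cyano in place of bromo on an aromatic carbon). Going by the values given here, no nitrile analogue has been measured yet. The closest evidence is the modest change at this same place, a 3.6-fold higher number from compound 2 to compound 3 (0.56 log units; beyond the scatter). Two further steps frame it: a 1.5-fold lower number from compound 1 to compound 2 (0.18 log units; within the scatter), within the scatter, and a 2.4-fold higher number from compound 1 to compound 3 (0.37 log units; beyond the scatter), modest. With bromo leaving compound 3, a modest step to a lower number is expected in this assay, with the direction resting on a 3.6-fold higher number from compound 2 to compound 3 (0.56 log units; beyond the scatter). The expected change is a 2.1-fold lower number from compound 3 to compound 4 (0.32 log units; beyond the scatter). Compound 4 is estimated at 7000 nM, with an expected range of 3000 nM to 16000 nM.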

Compound 4, half-maximal inhibitory concentration: 5920 nM
Beside the measured number, compound 4's estimate is 1.2-fold (0.07 log units) above it; low and high end bracket the measured number.
By their numbers in this assay, from the lowest: compounds 2, 4 and 1 (each within the scatter of the next); then compound 3.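

In this assay, replacing bromo with cyano on this aromatic carbon gives a 2.4-fold lower number from compound 3 to compound 4 (0.39 log units; beyond the scatter), so the higher number of compound 3 does not extend to every replacement of fluoro at this position. Cyano remains within the scatter of fluoro, a 1.5-fold higher number from compound 2 to compound 4 (0.17 log units; within the scatter), and of the hydrogen on the ring nitrogen, a 1.0-fold lower number from compound 1 to compound 4 (0.02 log units; within the scatter), leaving bromo as the only one of these sulfonyl substituents set apart in this series. As far as these compounds go, whether a methoxy group, an amine or a carboxylic acid on this aromatic carbon would track cyano and fluoro or bromo remains open. Nothing available explains why bromo stands apart.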